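Alkynyl furan variation on the shared core

The source may report more compounds than this note shows. Statements on the series, on what has been measured and on what is new or still open speak of the compounds shown alone.

Measured so far:
compound 1, `CNC(=O)[C@@]12C[C@@H]1[C@@H](n1cnc3c(NC)nc(C#Cc4ccc(F)cc4)nc31)[C@H](O)[C@@H]2O`: 27%
compound 2, `CNC(=O)[C@@]12C[C@@H]1[C@@H](n1cnc3c(NC)nc(C#Cc4cc(C)c(C)o4)nc31)[C@H](O)[C@@H]2O`: 15%

In an assay on CHO cells for displacement of a labelled ligand from adenosine receptor A1 (Homo sapiens), read by scintillation counting, with a stated time of 60 min, tested at 10 uM (on this read-out higher numbers stand for more inhibition at the one concentration tested (going by the name of the read-out) and lower numbers for less inhibition), compound 2 gives the lowest of the two numbers; the nearest is compound 1, which lies higher by the step of a number 12 percentage points lower from compound 1 to compound 2 (beyond the scatter). Compound 3, `CCc1ccc(C#Cc2nc(NC)c3ncn([C@H]4[C@H](O)[C@H](O)[C@]5(C(=O)NC)C[C@H]45)c3n2)o1`, has not been measured. It differs from compound 2 as follows: 5-ethylfuran-2-yl in place of 4,5-dimethylfuran-2-yl on a triple-bonded carbon. Going by the values given here, the one measured step exchanges an aryl group for a furan on the triple-bonded carbon; no measured step alters the substitution pattern on a furan itself, so that step bears only loosely on this change. Compound 3 is therefore expected to stay near compound 2 in this assay, with a step of a number 2 percentage points higher from compound 2 to compound 3 (within the scatter) that is expected to lie within the scatter. The estimate for compound 3 is 17%, with a range from 5% to 32%.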

Compound 3, a percentage reported as inhibition, at one concentration (the size of the read-out at that concentration, not a potency): 18%
Compound 3: middle estimate off by 1 percentage points, on the low side; low and high end bracket the measured number.
By their numbers in this assay, from the lowest: compounds 2, 3 and 1 (each within the scatter of the next, the first and the last beyond it).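

In this assay, 5-ethylfuran-2-yl in place of 4,5-dimethylfuran-2-yl on a triple-bonded carbon gives a number 3 percentage points higher from compound 2 to compound 3 (within the scatter) and so does not separate these two furans, which have the same atoms joined differently. Exchanging 4-fluorophenyl for a furan at this position no longer reads the same for every furan: a number 12 percentage points lower from compound 1 to compound 2 (beyond the scatter) stands against a number 9 percentage points lower from compound 1 to compound 3 (within the scatter) in the same assay, so the furan exchange is beyond the scatter in only one of the two cases. Nothing available bears on why the numbers fall as they do.

On these data alone, whether a longer chain such as n-butyl on the furan, or an amine or a carboxylic acid on the aryl or furan ring, would move the number at this position stays open. A read-out at one concentration also leaves the potency of all three compounds open.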